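From Cyclopropylamine to Cyclohexylamine on a Fused Core

This account rests on a few compounds, and the source may have more. Where it says the series, first, only, none or still open, it means among the compounds named here.

Three compounds of this series were tested in a functional assay on PC-3 cells (Homo sapiens) for cytotoxicity, read by sulforhodamine B assay, with a stated time of 72 h; a lower number here means a stronger inhibitor, a higher number a weaker inhibitor. Compound 1 `Nc1sc(-c2ccccc2)c(-c2ccc(Cl)cc2)c1C(=O)NC1CC1` gives 17100 nM in this assay. Compound 2 `Nc1sc(-c2ccc(Cl)cc2)c(-c2ccc(Cl)cc2)c1C(=S)NC1CCCC1` gives 29000 nM in this assay. Compound 3 `Clc1ccc(-c2sc3ncnc(NC4CC4)c3c2-c2ccc(Cl)cc2)cc1` has no number in this assay; its result is a limit of the assay, recorded as > 50000 nM. This is the limit described in the limit of > 50000 nM in this assay, at which 1 of the 3 values shown sits, so for compound 3 only a range is known, at the weak end of what was measured.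

Compound 4 `Clc1ccc(-c2sc3ncnc(NC4CCCCC4)c3c2-c2ccc(Cl)cc2)cc1` has not yet been measured in this assay. It differs from compound 3 in one place: cyclohexyl in place of cyclopropyl on a nitrogen on an aromatic ring, or, cut one bond further out, cyclopropylamino to cyclohexylamino. Going by the values given here, no comparable step exists among the measured compounds, so no direction can be read from them. Compound 3 stands at the limit, and the data give no ground to expect more than a movement within the scatter. Compound 4 is expected to give about 45000 nM in this assay, between 15000 nM and 120000 nM, with a real chance that only a limit is reported again. The estimated step from compound 3 to compound 4 is an at least 1.1-fold lower number from compound 3 to compound 4 (0.04 log units; that floor lies within the scatter).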

Compound 4, half-maximal inhibitory concentration: > 50000 nM
Compound 4 ended at the assay's limit (the forecaster's own chance of this, stated with the estimate: 55%); middle value at least 1.1-fold (0.04 log units) away from the limit.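

Compound 3 and compound 4 both ended at the limit of this assay, so the step between them, cyclohexyl in place of cyclopropyl on a nitrogen on an aromatic ring, cannot be read. The compounds shown leave open whether this change moves the value at all, and in which direction.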